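The source may hold more compounds than are shown below. What is called first, only, known or untested is meant among the compounds shown, and "the series" means these compounds.

Of the compounds shown here, three sharing one core have been tested in an assay on isolated protein (Oryctolagus cuniculus) with Thromboxane-A synthase (Homo sapiens) as the target, tested at 1 uM; a higher number here means more inhibition at the concentration tested (going by the name of the read-out), a lower number less inhibition. Compound 1 `CCn1nc(-c2cccnc2)c2ccccc2c1=O` gives 87%. Compound 2 `O=c1c2ccccc2c(-c2cccnc2)nn1CCSc1nccs1` gives 97%, and compound 3 `O=c1c2ccccc2c(-c2cccnc2)nn1CCCCSc1ncccn1` gives 96%. On these numbers compound 3 stands second highest of the three, closest to compound 2 and farthest from compound 1, yet every gap is within the scatter: a number 10 percentage points higher from compound 1 to compound 2 (within the scatter), a number 9 percentage points higher from compound 1 to compound 3 (within the scatter) and a number 1 percentage points lower from compound 2 to compound 3 (within the scatter).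

Compound 4 `CC(C)NC(=O)CCCn1nc(-c2cccnc2)c2ccccc2c1=O` differs from compound 3 only in the chain on the aromatic nitrogen: isopropylcarbamoyl in place of ((pyrimidin-2-yl)sulfanyl)methyl on a saturated chain carbon, three bonds along the chain from an aromatic nitrogen. The three measured steps all alter that same chain, from hydrogen to a thiazolyl sulfanyl group or to a pyrimidinyl sulfanyl chain, and none moved the inhibition beyond the scatter. For compound 4 the expectation is therefore no step beyond the scatter, so that a number 6 percentage points lower from compound 3 to compound 4 (within the scatter) is estimated. Compound 4 is expected to give 90%, with a range from 70% to 99%.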

Compound 4, a percentage reported as inhibition, at one concentration (the size of the read-out at that concentration, not a potency): 89%
The estimate for compound 4 lay 1 percentage points above the measured number, within the range that was stated.
By their numbers in this assay, from the lowest: compounds 1, 4, 3 and 2 (each within the scatter of the next).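

In this assay the chain on the aromatic nitrogen can now end in isopropylcarbamoyl, a group with no ring and no sulfur, and the result stays within the scatter of the chains that carry a sulfanyl-linked aromatic ring (a number 7 percentage points lower from compound 3 to compound 4 (within the scatter); a number 8 percentage points lower from compound 2 to compound 4 (within the scatter)). Set against the plain ethyl chain of compound 1, adding this amide also makes no step beyond the scatter (a number 2 percentage points higher from compound 1 to compound 4 (within the scatter)), so a change in the chain's end this large has still not separated the compounds. No measurement here accounts for how small these steps are.

All four compounds were read at a single concentration and lie within the scatter of one another, so their order remains unsettled. As far as these compounds go, whether a chain ending in an amine or a carboxylic acid would give a step beyond the scatter at this position remains open.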